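Formyl for ethyl on the pendant phenyl ring

The source may hold more compounds than are shown below. What is called first, only, known or untested is meant among the compounds shown, and "the series" means these compounds.

Working notes on the series. Of the compounds shown here, two have been measured in a functional assay on NCI-H322M cells (Homo sapiens) for inhibition, read by sulforhodamine B assay, with a stated time of 48 h, tested at 10 uM; a lower number here means less inhibition, a higher number more inhibition at the concentration tested (going by the name of the read-out). Compound 1 `O=Cc1ccc(-c2cn3ccnc3c(-c3ccc4ncn(C5CCCCC5)c4c3)n2)cc1` gives 11.2% in this assay. Among the compounds with values here, compound 2 `CCc1ccc(-c2cn3ccnc3c(-c3ccc4ncn(Cc5ccccc5)c4c3)n2)cc1` gives 0.89% in this assay, the lower of the two numbers, with compound 1 as its only neighbour at a gap beyond the usual scatter. Within the data shown here, no two measured compounds differ in one place only, so no single-change step can be read from the data; compound 1 and compound 2 differ both in the group on the aromatic carbon and elsewhere in the structure, and their gap cannot be assigned to either change.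

Compound 3 `O=Cc1ccc(-c2cn3ccnc3c(-c3ccc4ncn(Cc5ccccc5)c4c3)n2)cc1` has not yet been measured. It differs from compound 2 in one place: formyl in place of ethyl on an aromatic carbon. Compound 3 shares the formyl group with compound 1 and the rest of its structure with compound 2. The step of a number 4.1 percentage points higher from compound 2 to compound 3 (within the scatter) is expected to be small and upward, within the scatter, because compound 1 with the same formyl group gives only 11.2%. Compound 3 is therefore estimated at 5%, with a range from -5% to 15%.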

Compound 3, a percentage reported as inhibition, at one concentration (the size of the read-out at that concentration, not a potency): 11.2%
Beside the measured number, compound 3's estimate is 6.2 percentage points below it; low and high end bracket the measured number.
By their numbers in this assay, from the lowest: compound 2; then compounds 1 and 3 (each within the scatter of the next).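

In this assay, formyl in place of ethyl on the aromatic carbon para to a large group gives a number 10.3 percentage points higher from compound 2 to compound 3 (beyond the scatter), so the group at this position does shift the read-out when benzyl sits on the aromatic nitrogen. Benzyl in place of cyclohexyl on that nitrogen gives no change at the digits printed from compound 1 to compound 3 (within the scatter), so with formyl on the phenyl ring, the two nitrogen groups cannot be told apart in this read-out. Even so, the step is modest, and compound 3 gives only 11.2% at the concentration tested, so 4-formylphenyl does not bring the series to substantial inhibition.

Nothing on hand accounts for either step.

From the compounds shown here alone, whether an amine or a carboxylic acid at this position, or a chain longer than ethyl, would shift the read-out further remains open. The flat step on the nitrogen is also established only with formyl on the phenyl ring, and whether it holds with ethyl there, or with other groups on the nitrogen, cannot be said from these compounds.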